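A few compounds are considered here, and "the series" means these few. Any claim that something is new, unique, unknown or untested is made for them only; others in the source may bear on it.

Measured so far in an ADME assay for pharmacokinetics, read by LC-MS, in phosphate buffer, with a stated time of 72 h, at pH 7.4, tested at 250 uM; on this read-out lower numbers stand for a shorter-lived compound and higher numbers for a longer-lived compound:
compound 1 `C=CS(=O)(=O)c1cc(C(F)(F)F)cc(C(F)(F)F)c1` gives < 0.017 h
compound 2 `O=C1C=CC(=O)N1c1cc(C(F)(F)F)cc(C(F)(F)F)c1` gives < 0.017 h
compound 3 `C=Cc1cc(C(F)(F)F)cc(C(F)(F)F)c1` gives > 50 h

The value of compound 1 is a limit of this assay, not a number (the limit of < 0.017 h in this assay, at which 2 of the 3 values shown sit). The value of compound 2 is the same kind of limit. The value of compound 3 is a limit at the other end of the read-out (the limit of > 50 h in this assay, at which 1 of the 3 values shown sits), so compound 3 stands at the top of the three values shown. Between the two low limits the step that the two limits leave unreadable from compound 1 to compound 2 cannot be read. The steps of an at least 2900-fold higher number from compound 1 to compound 3 (3.46 log units; beyond the scatter) and an at least 2900-fold higher number from compound 2 to compound 3 (3.46 log units; beyond the scatter) are both large and both run toward compound 3.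

Compound 4 `C#Cc1cc(C(F)(F)F)cc(C(F)(F)F)c1` differs from compound 3 by ethynyl in place of vinyl on an aromatic carbon. Among the measured compounds shown here, none of the measured steps swaps vinyl for ethynyl; the two large steps remove vinylsulfonyl or the five-membered ring and leave vinyl behind. For the measured compounds named here, the only hydrocarbon-substituted analogue measured, compound 3, sits at the upper limit. Compound 4 is therefore expected to stay near that upper limit, with a step that the limit leaves unreadable from compound 3 to compound 4 expected to lie within the scatter. The estimate for compound 4 in this assay is 60 h, with a range from 15 h to 250 h.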

Compound 4, half-life: 1.6 h
Compound 4: middle estimate off by 38-fold (1.57 log units), on the high side; measured number below the stated range.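

In this assay, ethynyl in place of vinyl gives an at least 31-fold lower number from compound 3 to compound 4 (1.49 log units; beyond the scatter), so a two-carbon group on this aromatic carbon does not by itself secure a long half-life, even with the heavy-atom count and the lack of rings, donors and acceptors unchanged. The other two steps, an at least 94-fold higher number from compound 2 to compound 4 (1.97 log units; beyond the scatter) and an at least 94-fold higher number from compound 1 to compound 4 (1.97 log units; beyond the scatter), put ethynyl clear of the low end of the read-out as well as short of the high end. Compound 3 stands at a limit, not a number, so the first step is a bound and not a size: the limit of > 50 h in this assay, at which 1 of the 4 values shown sits.

The compounds shown leave open why a triple bond here gives a shorter half-life than a double bond. They also leave open where a nitrile, an amine or a longer chain such as propyl would fall on this aromatic carbon.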